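Triazole series: a second ring chloro and cell toxicity

A few compounds are considered here, and "the series" means these few. Any claim that something is new, unique, unknown or untested is made for them only; others in the source may bear on it.

Measured compounds:
compound 1 `CC[C@H](CCn1cncn1)c1ccccc1`: 97.7 ug/mL
compound 2 `CC[C@H](CCn1cncn1)c1ccc(Cl)cc1`: 50.6 ug/mL
compound 3 `CCCC[C@H](CCn1cncn1)c1ccc(Cl)cc1`: 20.2 ug/mL

In an ADME assay on HEp-2 cells (Homo sapiens) for cytotoxicity, read by MTT assay, with a stated time of 3 days (on this read-out higher numbers stand for lower toxicity in this test and lower numbers for higher toxicity in this test), compound 1 gives 97.7 ug/mL. Compound 2 carries the change chloro in place of hydrogen on an aromatic carbon and gives 50.6 ug/mL; the step is a 1.9-fold lower number from compound 1 to compound 2 (0.29 log units; within the scatter). Compound 3, with a 2.5-fold lower number from compound 2 to compound 3 (0.40 log units; beyond the scatter), gives 20.2 ug/mL and has the lowest number of the three, with compound 2 nearest and compound 1 furthest, both beyond the scatter.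

Compound 4 `CCCC[C@H](CCn1cncn1)c1ccc(Cl)cc1Cl` is not yet measured. It differs from compound 3 by chloro in place of hydrogen on an aromatic carbon. Compared with the change from compound 1 to compound 2, the entering group is the same, but the place is not the same word for word: there it sits para to a large group, here ortho to a large group and meta to a chloro group. It is therefore the same kind of change, not the same change. The difference between the core of compound 1 and the core of compound 3 is not broken down here.

Going by the values given here, the only guide is the step from compound 1 to compound 2, which stayed within the scatter. For compound 4 a step of about the same size is expected, a 1.7-fold lower number from compound 3 to compound 4 (0.23 log units; within the scatter), because a 1.9-fold lower number from compound 1 to compound 2 (0.29 log units; within the scatter) gives the one comparable case. The estimate for compound 4 in this assay is 12 ug/mL, expected between 5 ug/mL and 30 ug/mL.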

Compound 4, half-maximal cytotoxic concentration: 13.4 ug/mL
Compound 4: middle estimate off by 1.1-fold (0.05 log units), on the low side, and the stated range covers the measured number.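

In this assay, chloro entering ortho to a large group and meta to a chloro group gives a 1.5-fold lower number from compound 3 to compound 4 (0.18 log units; within the scatter), and set beside the earlier chloro step on the other core, the two steps agree: the same change on two cores in this assay, a 1.9-fold lower number (0.29 log units; within the scatter) from compound 1 to compound 2 and a 1.5-fold lower number (0.18 log units; within the scatter) from compound 3 to compound 4, 1.3-fold (0.11 log units) apart, within the scatter of two such steps. In this small set, then, the chloro change carries from the core of compound 1 to the core of compound 3 without a visible difference in step size, and neither step stands clear of the usual scatter of this read-out. Going by these compounds alone, this does not show that chloro lowers the number in a reliable way, nor that the agreement would hold on other cores, and with only two pairs, which differ in both core and ring place, the influence of the core cannot be separated from that of the place.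

Still open, as far as these compounds go, is whether chloro at this same ring place gives a comparable step on the core of compound 1, and whether a longer chain on the core of compound 3 would add to the step seen with ethyl. Also open, from the compounds shown here alone, is how fluoro, methoxy or trifluoromethyl in place of chloro, or an amine or a carboxylic acid on the chain, would read in this assay.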